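A few compounds are considered here, and "the series" means these few. Any claim that something is new, unique, unknown or untested is made for them only; others in the source may bear on it.

Among the compounds with values here, in a functional assay on NB1 cells (Homo sapiens) for cytotoxicity, read by MTT assay, with a stated time of 3 days (a higher number here means a weaker inhibitor, a lower number a stronger inhibitor), compound 2 `Cc1ccc(S(=O)(=O)N2CCN(c3nc(SCc4nc5ccccc5[nH]4)nc(-c4ccccc4)c3C#N)CC2)cc1` gives 6.75 nM, the higher of the two numbers so far, while compound 1 `N#Cc1c(-c2ccccc2)nc(SCc2nc3ccccc3[nH]2)nc1N1CCN(S(=O)(=O)c2ccccc2)CC1` gives 3.28 nM. Compound 3 `N#Cc1c(-c2ccccc2)nc(SCc2nc3ccccc3[nH]2)nc1N1CCN(S(=O)(=O)c2ccccc2[N+](=O)[O-])CC1` carries 2-nitrophenyl in place of 4-methylphenyl on a sulfonyl sulfur. Within the data shown here, the only measured step that bears on this change is modest: a 2.1-fold higher number from compound 1 to compound 2 (0.31 log units; beyond the scatter), with methyl in place of hydrogen on an aromatic carbon. Among the measured compounds shown here, no compound with 2-nitrophenyl has been measured, so no clear direction can be set, and little beyond the scatter is expected. The expected result in this assay is a 1.4-fold lower number from compound 2 to compound 3 (0.13 log units; within the scatter). For compound 3 the estimated value is 5 nM, with an expected range of 1.5 nM to 18 nM.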

Compound 3, half-maximal inhibitory concentration: 2.5 nM
Beside the measured number, compound 3's estimate is 2.0-fold (0.30 log units) above it; measured number inside the range.
By their numbers in this assay, from the lowest: compounds 3 and 1 (each within the scatter of the next); then compound 2.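

In this assay the aryl group on the sulfonyl sulfur accepts 2-nitrophenyl: the change from 4-methylphenyl gives a 2.7-fold lower number from compound 2 to compound 3 (0.43 log units; beyond the scatter) and so recovers the number lost with methyl. Nitro in place of hydrogen gives a 1.3-fold lower number from compound 1 to compound 3 (0.12 log units; within the scatter) and so no separation from compound 1, which means this substituent, unlike methyl, does not shift the number beyond the scatter. Nothing available explains either step.

The compounds shown do not separate the identity of the substituent from its place on the ring, since 2-methylphenyl and 4-nitrophenyl are absent from them. Going by these compounds, how an amine or a carboxylic acid on this phenyl ring would behave also remains open.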